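A Change at the Aryl Ring of Compound 2

The source may report more compounds than this note shows. Statements on the series, on what has been measured and on what is new or still open speak of the compounds shown alone.

Measured compounds in a functional assay on HT-29 cells (Homo sapiens) for inhibition, read by MTT assay, with a stated time of 72 h; on this read-out lower numbers stand for stronger inhibition and higher numbers for weaker inhibition:
compound 1 `COc1cc2c(Oc3ccc(NC(=O)c4nn(-c5ccccc5C(F)(F)F)c(=O)cc4C)cc3F)ccnc2cc1OCCCN1CCCCC1` gives 170 nM
compound 2 `COc1cc2c(Oc3ccc(NC(=O)c4nn(-c5ccccc5C(F)(F)F)c(=O)cc4C)cc3F)ccnc2cc1OCCCN1CCC(C)CC1` gives 180 nM
compound 3 `COc1cc2c(Oc3ccc(NC(=O)c4nn(-c5ccccc5C(F)(F)F)c(=O)cc4C)cc3F)ccnc2cc1OCCCN1CCN(C)CC1` gives 170 nM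

Compound 2 shows the highest of the three numbers, but its steps to the others are small: a 1.1-fold higher number from compound 1 to compound 2 (0.02 log units; within the scatter) and a 1.1-fold lower number from compound 2 to compound 3 (0.02 log units; within the scatter), both within the scatter, so the three compounds cannot be told apart on this read-out.

Compound 4 `COc1ccc(-n2nc(C(=O)Nc3ccc(Oc4ccnc5cc(OCCCN6CCC(C)CC6)c(OC)cc45)c(F)c3)c(C)cc2=O)cc1` differs from compound 2 by 4-methoxyphenyl in place of 2-(trifluoromethyl)phenyl on an aromatic nitrogen. Within the data shown here, none of the measured steps touches this part of the shared core; they all change the saturated ring at the chain end and leave the numbers essentially unchanged. Among the measured compounds shown here, there is therefore no measured step that bears directly on the new change, and the expectation must stay wide. Compound 4 is expected to give about 300 nM, in a range from 80 nM to 1200 nM, which means an expected step of a 1.7-fold higher number from compound 2 to compound 4 (0.22 log units; within the scatter), most likely a weaker or similar inhibition rather than a stronger one.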

Compound 4, half-maximal inhibitory concentration: 5450 nM
The estimate for compound 4 lay 18-fold (1.26 log units) below the measured number; the measured number lies above the stated range.
By their numbers in this assay, from the lowest: compounds 1, 3 and 2 (each within the scatter of the next); then compound 4.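

The aryl group on the aromatic nitrogen counts for far more in this assay than the saturated ring at the chain end. Putting 4-methoxyphenyl in place of 2-(trifluoromethyl)phenyl gives a large loss of inhibition (a 30-fold higher number from compound 2 to compound 4 (1.48 log units; beyond the scatter)), whereas the earlier changes at the chain end all stayed within the scatter. No measurement at hand gives a reason for this loss.

This single step swaps both the substituent and its place on the phenyl ring, so the compounds shown leave open which of the two matters. A 2-methoxyphenyl or a 4-(trifluoromethyl)phenyl group on the same nitrogen would separate them.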